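Methyl to methoxy on the pyridine-carbon of compound 2

This account rests on a few compounds, and the source may have more. Where it says the series, first, only, none or still open, it means among the compounds named here.

Measured compounds:
compound 1 `CC(C)N(CCN(C(=O)N(C)C)c1ccccn1)C(C)C` — 17%
compound 2 `Cc1ccnc(N(CCN(C(C)C)C(C)C)C(=O)N(C)C)c1` — 95%
compound 3 `Cc1cccc(N(CCN(C(C)C)C(C)C)C(=O)N(C)C)n1` — 87%

All three share one core and are read in a functional assay on the whole organism (stomach) for inhibition, with Canis familiaris (Canis lupus familiaris) as the target, at a dose of 20 mg/kg by the oral route; on this read-out higher numbers stand for a stronger effect at the one dose given and lower numbers for a weaker effect. Compound 2 stands highest of the three numbers; compound 3 is nearest, and a number 8 percentage points lower from compound 2 to compound 3 (within the scatter), so the two cannot be separated. Compound 1 is furthest: a number 78 percentage points higher from compound 1 to compound 2 (beyond the scatter) and a number 70 percentage points higher from compound 1 to compound 3 (beyond the scatter), so a methyl on an aromatic carbon of the core, at either of the two places tried, carries nearly the whole effect seen.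

Compound 4 `COc1ccnc(N(CCN(C(C)C)C(C)C)C(=O)N(C)C)c1` is not yet measured. It differs from compound 2 in one place:

methoxy in place of methyl on an aromatic carbon

For the measured compounds named here, no measured step exchanges methyl for methoxy; the only steps bearing on that carbon are the two methyl-for-hydrogen steps above, which were large and in the same direction. They show that a group on this carbon matters, but not whether methoxy will hold the effect that methyl gave. Given the large steps from compound 1, the expectation is that compound 4 keeps a substantial part of the activity of compound 2, with the estimated step of a number 20 percentage points lower from compound 2 to compound 4 (beyond the scatter) being a moderate fall and a wide range allowed for. The estimated value for compound 4 is 75%, between 35% and 98%.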

Compound 4, a percentage reported as inhibition, in the whole organism at one dose (the size of the read-out at that dose, not a potency): 84%
Compound 4: the middle estimate sits 9 percentage points below what was measured; low and high end bracket the measured number.
By their numbers in this assay, from the lowest: compound 1; then compounds 4, 3 and 2 (each within the scatter of the next, the first and the last beyond it).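

Methoxy on this aromatic carbon, opposite the ring nitrogen, also carries the effect in this assay, with a number 67 percentage points higher from compound 1 to compound 4 (beyond the scatter) and so a gain over hydrogen that is not confined to methyl. The exchange of methyl for methoxy gives a number 11 percentage points lower from compound 2 to compound 4 (beyond the scatter) and adds an oxygen and a hydrogen-bond acceptor at this place, so the step is modest and most of the effect gained over hydrogen remains. Nothing available on these compounds accounts for this modest fall.

As far as these compounds go, whether this carbon also keeps the effect with an amine, a hydroxyl, a chlorine or a longer chain such as ethyl remains open, as does the outcome of methoxy at the place that carries the methyl in compound 3. Each number comes from a single dose, so the compounds shown leave open how the effects of the methyl and methoxy compounds compare at other doses, and whether the methoxy step would be the same size at a lower dose.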